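Trimethoxyphenyl series: swapping the aryl on the saturated ring carbon

This account rests on a few compounds, and the source may have more. Where it says the series, first, only, none or still open, it means among the compounds named here.

Three compounds have numbers in a functional assay on BGC-823 cells (Homo sapiens) for antiproliferative activity, read by MTT assay, tested at 1 uM; on this read-out lower numbers stand for a weaker effect and higher numbers for a stronger effect at the one concentration tested. Compound 1 `COc1cc(C(=O)N/N=C/c2ccccc2C(F)(F)F)cc(OC)c1OC` gives 22.1%. Compound 2 `COc1cc(C2=NN(C(C)=O)C(c3cccc(OC)c3OC)O2)cc(OC)c1OC` gives 3.8%, and compound 3 `COc1cc(/C=N/NC(=O)c2cc(OC)c(OC)c(OC)c2)cc(OC)c1OC` gives -5%. Compound 2 thus stands second highest of the three: the gap to compound 3 lies within the scatter, so the two show no ordering, while compound 1 lies beyond the scatter above compound 2.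

Compound 4 `COc1cc(C2=NN(C(C)=O)C(c3cccc(C(F)(F)F)c3)O2)cc(OC)c1OC` has not been measured. It keeps the core of compound 2 and changes one group: 3-(trifluoromethyl)phenyl in place of 2,3-dimethoxyphenyl on a saturated ring carbon.

For the measured compounds named here, no step between measured compounds isolates this change. Going by the values given here, the only pointer is compound 1, which also carries a trifluoromethyl on its aryl and gives 22.1%, on a different core. A modest upward step in this assay is expected, of a size that may still sit within the scatter. The value for compound 4 is estimated at 11%, within -8% to 30%, corresponding to an expected step of a number 7.2 percentage points higher from compound 2 to compound 4 (within the scatter).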

Compound 4, a percentage reported as inhibition, at one concentration (the size of the read-out at that concentration, not a potency): 27.9%
Estimate against measurement, compound 4: 16.9 percentage points below, within the range that was stated.
By their numbers in this assay, from the lowest: compounds 3 and 2 (each within the scatter of the next); then compounds 1 and 4 (each within the scatter of the next).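

In this assay, the aryl on this saturated ring carbon proves to matter: 3-(trifluoromethyl)phenyl in place of 2,3-dimethoxyphenyl gives a number 24.1 percentage points higher from compound 2 to compound 4 (beyond the scatter). For the compounds shown here, this is the first comparison that isolates a single place on the shared core. The swap still alters several things at once, since two methoxy groups leave and a trifluoromethyl enters, and no measurement shown here accounts for the step.

From the compounds shown here alone, whether the gain comes from adding the trifluoromethyl or from losing the methoxy groups stays open, and a plain phenyl, or a phenyl carrying a single methoxy or a nitrile, would help separate the two. Also open, going by these compounds, is whether the acetyl group on the shared core can give way to a longer chain or an amine while keeping this level of effect.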